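From 3-carboxypyrrolidin-1-yl to 3-carboxyazetidin-1-yl

The compounds below may be only part of what the source reports. "The series", "measured", "known", "first", "only" and "open" are said of these compounds alone.

Values in a functional assay on B16-F10 cells (Mus musculus) for antiproliferative activity, read by CCK-8 assay, with a stated time of 48 h; a higher number here means a weaker inhibitor, a lower number a stronger inhibitor:
- Compound 1 `COc1ccc(/C=C\c2cc(OC)c(OC)c(OC)c2)cc1OCc1ccc(CN2CCCC[C@H]2C(=O)O)cc1`: > 10000 nM (a limit of the assay, not a number)
- Compound 2 `COc1ccc(/C=C\c2cc(OC)c(OC)c(OC)c2)cc1OCc1ccc(CNCCO)cc1`: 6600 nM
- Compound 3 `COc1ccc(/C=C\c2cc(OC)c(OC)c(OC)c2)cc1OCc1ccc(CN2CC[C@H](C(=O)O)C2)cc1`: 7000 nM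

For the measured compounds named here, compound 3, at 7000 nM, holds one of only two true numbers here, and those two do not separate: a 1.1-fold higher number from compound 2 to compound 3 (0.03 log units; within the scatter).

Compound 4 `COc1ccc(/C=C\c2cc(OC)c(OC)c(OC)c2)cc1OCc1ccc(CN2CC(C(=O)O)C2)cc1` makes one change on a saturated chain carbon bound to an aromatic carbon: 3-carboxyazetidin-1-yl in place of 3-carboxypyrrolidin-1-yl on a saturated chain carbon bound to an aromatic carbon.

The closest measured change is another swap at that place, an at least 1.4-fold lower number from compound 1 to compound 3 (0.15 log units; that floor lies within the scatter). It starts from a limit, so it gives only a floor, as does an at least 1.5-fold lower number from compound 1 to compound 2 (0.18 log units; that floor lies within the scatter). No step beyond the scatter is therefore expected in this assay, and the expected change is a 1.1-fold lower number from compound 3 to compound 4 (0.03 log units; within the scatter).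

For compound 4 the estimated value is 6500 nM, with an expected range from 3000 nM to 10000 nM.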

Compound 4, half-maximal inhibitory concentration: > 10000 nM
Compound 4 was reported as a limit (the forecaster's own chance of this, stated with the estimate: 20%); at least 1.5-fold (0.18 log units) between middle value and limit.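

In this assay compound 4 is reported only as a limit, not a number, so 3-carboxyazetidin-1-yl at this saturated chain carbon bound to an aromatic carbon yields no measured potency. The data give only floors: an at least 1.4-fold higher number from compound 3 to compound 4 (0.15 log units; that floor lies within the scatter), and an at least 1.5-fold higher number from compound 2 to compound 4 (0.18 log units; that floor lies within the scatter). The step from compound 1 to compound 4 cannot be read, and the limit now recurs among these compounds: the limit of > 10000 nM in this assay, at which 2 of the 4 values shown sit.

From the compounds shown here alone, how far the true value of compound 4 lies past its limit stays open. Also open, going by these compounds, is whether a morpholin-4-yl group or the methyl ester of these acids would fare better at this place.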